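This account rests on a few compounds, and the source may have more. Where it says the series, first, only, none or still open, it means among the compounds named here.

In an ADME assay on MT4 cells (Homo sapiens) for cytotoxicity, read by MTT assay, with a stated time of 4 days (on this read-out lower numbers stand for higher toxicity in this test and higher numbers for lower toxicity in this test), compound 1 `CCCNc1nc(C(C)c2c(F)cccc2F)c(C)c(=O)[nH]1` gives 35000 nM. Compound 2 `Cc1c(C(C)c2c(F)cccc2F)nc(N(C)C(C)C)[nH]c1=O` gives > 81000 nM, which is a limit. Compound 3 `Cc1c(C(C)c2c(F)cccc2F)nc(N2CCCC2)[nH]c1=O` gives > 78000 nM, also a limit, so it has no exact number. Compound 4 `Cc1c(C(C)c2c(F)cccc2F)nc(N2CCCCC2)[nH]c1=O` differs from compound 3 at one place: piperidin-1-yl in place of pyrrolidin-1-yl on an aromatic carbon, with piperidin-1-yl in place of pyrrolidin-1-yl on an aromatic carbon. Two measured changes at this place are readable, an at least 2.3-fold higher number from compound 1 to compound 2 (0.36 log units; beyond the scatter) and an at least 2.2-fold higher number from compound 1 to compound 3 (0.34 log units; beyond the scatter), and both are modest at least. The third, a step that the two limits leave unreadable from compound 2 to compound 3, gives no size. None of them swaps one ring for another, so no step beyond the scatter is expected in this assay, in either direction. The expected step is an at least 1.1-fold lower number from compound 3 to compound 4 (0.04 log units; that floor lies within the scatter). For compound 4 the estimate is 70000 nM, with an expected range from 30000 nM to 130000 nM.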

Compound 4, half-maximal cytotoxic concentration: > 75000 nM
Compound 4 gave a limit, no number; the forecaster's own chance of this, stated with the estimate: 60%; middle value at least 1.0-fold (0.02 log units) from the limit.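

Compound 4 gives a limit, not a number, in this assay: the limit of > 75000 nM in this assay, at which 1 of the 4 values shown sits.

Piperidin-1-yl in place of propylamino gives an at least 2.1-fold higher number from compound 1 to compound 4 (0.33 log units; beyond the scatter). A six-membered ring at this position therefore sides with the five-membered ring of compound 3 and the isopropyl(methyl)amino group of compound 2 in its step from compound 1.

Going by these compounds, the steps among compound 2, compound 3 and compound 4 cannot be read, so any effect of ring size here stays open. On these data alone, how a morpholin-4-yl group at this position would read also remains open.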